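A few compounds are considered here, and "the series" means these few. Any claim that something is new, unique, unknown or untested is made for them only; others in the source may bear on it.

Of the compounds shown here, two have been measured in a functional assay on PC-3 cells (Homo sapiens) for cytotoxicity, read by MTT assay, with a stated time of 72 h; a higher number here means a weaker inhibitor, a lower number a stronger inhibitor. Compound 1 `COc1cccc(/C=C/C(=O)Nc2cc(OC)c(OC)c(OC)c2)c1` gives 2100 nM in this assay. Compound 2 `COc1ccc(/C=C/C(=O)Nc2cc(C(=O)c3cc(OC)c(OC)c(OC)c3)ccc2OC)cc1`, built on a larger core, gives 11100 nM in this assay, the higher of the two numbers, and the gap to compound 1 lies beyond the scatter.

Compound 3 `COc1cc(/C=C/C(=O)Nc2cc(C(=O)c3cc(OC)c(OC)c(OC)c3)ccc2OC)ccc1F` has not been measured. It keeps the core of compound 2 and differs in one place: 4-fluoro-3-methoxyphenyl in place of 4-methoxyphenyl on a double-bonded chain carbon bound to a double-bonded chain carbon. Among the measured compounds shown here, no measured pair shows what this exchange does, so the expectation rests on compound 2 alone, as the one measured compound with the same core. A fluorine added to the ring, with the methoxy moved on that ring, is a modest change in size, so a small shift is expected, in no firm direction.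

Compound 3 is therefore expected to give about 9000 nM in this assay, within a range from 3000 nM to 27000 nM. The expected step of a 1.2-fold lower number from compound 2 to compound 3 (0.09 log units; within the scatter) is estimated to stay within the scatter.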

Compound 3, half-maximal inhibitory concentration: 14100 nM
Beside the measured number, compound 3's estimate is 1.6-fold (0.19 log units) below it, within the range that was stated.
By their numbers in this assay, from the lowest: compound 1; then compounds 2 and 3 (each within the scatter of the next).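

Among the compounds shown here, the exchange of 4-methoxyphenyl for 4-fluoro-3-methoxyphenyl, on a double-bonded chain carbon bound to a double-bonded chain carbon, gives the first step that can be read in this assay: a 1.3-fold higher number from compound 2 to compound 3 (0.10 log units; within the scatter), so the two compounds cannot be told apart here. On this core, then, the ring can carry an added fluorine and a moved methoxy without a change that this read-out can resolve, although this rests on a single pair. Nothing measured here offers a reason for this result.

Still open, on these data alone, is whether this position responds to a larger change, such as an amine or a carboxylic acid on that ring, or a longer chain in place of the ring. A single pair also cannot show whether the same exchange would behave alike on a different core.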